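Cytotoxicity notes: aryl swap from compound 3 to compound 4

The compounds below may be only part of what the source reports. "The series", "measured", "known", "first", "only" and "open" are said of these compounds alone.

Measured so far in an ADME assay on Huh-7 cells (Homo sapiens) for cytotoxicity, read by MTT assay, with a stated time of 48 h; on this read-out higher numbers stand for lower toxicity in this test and lower numbers for higher toxicity in this test:
- compound 1 `CC(c1ccc(N(CCCCN(C)C)C(=O)O)cc1)n1nc(-c2ccc(F)cc2)c2ccccc2c1=O`: 15200 nM
- compound 2 `CN(C)CCCC(=O)Nc1ccc(CN2N=C(c3ccc(F)cc3)C3C=CC=CC3C2=O)cc1`: 38200 nM
- compound 3 `CN(C)CCCCOC(=O)Nc1ccc(Cn2nc(-c3cncnc3)c3ccccc3c2=O)cc1`: 65300 nM

Compound 3 gives the highest number of the three in this assay. Its nearest neighbour is compound 2, whose value sits within the scatter of that of compound 3, so no order between these two can be read from the numbers. The furthest is compound 1, whose number lies beyond the scatter below that of compound 3; compound 1 is therefore more toxic in this test than compound 3. Among the compounds with values here, no pair of measured compounds differs in a single place, so no isolated structural step is available within the measured set.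

Compound 4 `CN(C)CCCCOC(=O)Nc1ccc(Cn2nc(-c3cccc(C(F)(F)F)c3)c3ccccc3c2=O)cc1` differs from compound 3 in one place: 3-(trifluoromethyl)phenyl in place of pyrimidin-5-yl on an aromatic carbon. Nothing measured here isolates this change, and the three values span a modest spread. The step from compound 3 to compound 4 is expected to be small and toward higher toxicity in this test, a 2.0-fold lower number from compound 3 to compound 4 (0.31 log units; beyond the scatter), though an outcome within the scatter is plausible. For compound 4 the expected value in this assay is 32000 nM, with a range from 10000 nM to 80000 nM.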

Compound 4, half-maximal cytotoxic concentration: 11600 nM
Compound 4: the middle estimate sits 2.8-fold (0.44 log units) above what was measured, within the range that was stated.
By their numbers in this assay, from the lowest: compounds 4 and 1 (each within the scatter of the next); then compounds 2 and 3 (each within the scatter of the next).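

In this assay, this position on an aromatic carbon next to the ring nitrogen gives the series its first readable single change: 3-(trifluoromethyl)phenyl in place of pyrimidin-5-yl produces a 5.6-fold lower number from compound 3 to compound 4 (0.75 log units; beyond the scatter), so compound 4 is more toxic in this test than compound 3. The aryl group at this position is therefore not neutral for this read-out, since a ring with 2 hetero atoms and 2 hydrogen-bond acceptors gives way to a carbon-only ring with 0 acceptors, and the group grows from 6 to 10 heavy atoms, while the rest of the structure stays the same. No measurement here accounts for the step, and the loss of the ring nitrogens, the arrival of the trifluoromethyl group and the added size cannot be told apart.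

The compounds shown leave open how much of the step belongs to the trifluoromethyl group and how much to the loss of the ring nitrogens, a question that a plain phenyl or a pyridin-3-yl group at this position would address. Also open, as far as these compounds go, is whether the step holds when the dimethylamino chain end is replaced by a carboxylic acid.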